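This account rests on a few compounds, and the source may have more. Where it says the series, first, only, none or still open, it means among the compounds named here.

Compound 2 `C#CC(CCC)OC[n+]1ccn(C)c1/C=N/O` gives 8.02 in a physicochemical assay for acid dissociation. Among the compounds with values here, of the two numbers measured so far it stands highest; its nearest neighbour is compound 1 `C=CC(CCC)OC[n+]1ccn(C)c1/C=N/O`, which in this assay gives 7.99, the two values lying within the scatter of each other. Within the data shown here, the single step measured at this place, a number 0.03 log units higher from compound 1 to compound 2 (within the scatter), stayed within the scatter.

Compound 3 `CCCC(OC[n+]1ccn(C)c1/C=N/O)c1ccccc1` has not yet been measured in this assay. Against compound 2 it differs as follows: phenyl in place of ethynyl on a saturated chain carbon bound to an oxygen on a saturated carbon and a saturated chain carbon. Among the measured compounds shown here, only one measured step bears on this change, the exchange of groups on the same saturated chain carbon bound to an oxygen, and that step did not leave the scatter. No step beyond the scatter is therefore expected in this assay, and for compound 3 the expected step is a number 0.02 log units lower from compound 2 to compound 3 (within the scatter). Compound 3 is estimated at 8, with a range from 7.7 to 8.3.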

Compound 3, acid dissociation constant: 8.03
The estimate for compound 3 lay 0.03 log units below the measured number; low and high end bracket the measured number.
By their numbers in this assay, from the lowest: compounds 1, 2 and 3 (each within the scatter of the next).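

In this assay, phenyl on the saturated chain carbon bound to an oxygen on a saturated carbon and a saturated chain carbon stays within the scatter of both earlier groups (a number 0.01 log units higher from compound 2 to compound 3 (within the scatter); a number 0.04 log units higher from compound 1 to compound 3 (within the scatter)). Phenyl enters with 6 heavy atoms and one six-membered aromatic ring of carbon only where ethynyl had 2 heavy atoms and no ring, so a ring at this place is now covered, and vinyl, ethynyl and phenyl cannot be told apart by this read-out. No supporting measurement bears on why the numbers stay together.

All three groups at this place contain carbon only, so an amine or a carboxylic acid there remains an open case. Whether either would take the number beyond the scatter cannot be read from these compounds.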